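Notes on compound 3: methoxy replaces hydrogen on phenyl

The compounds below may be only part of what the source reports. "The series", "measured", "known", "first", "only" and "open" are said of these compounds alone.

Compound 1 `c1ccc(-c2nnc(-c3c[nH]c4ccccc34)o2)cc1` is the parent of the pair under review. In a functional assay on LNCaP cells (Homo sapiens) for cytotoxicity, read by MTT assay (on this read-out higher numbers stand for weaker inhibition and lower numbers for stronger inhibition), compound 1 gives only a limit, > 1000000 nM, and not a number (the limit of > 1000000 nM in this assay, at which 1 of the 2 values shown sits). Compound 2 `c1cncc(-c2nnc(-c3c[nH]c4ccccc34)o2)c1` carries pyridin-3-yl in place of phenyl on an aromatic carbon; in this assay compound 2 gives 69400 nM. For the measured compounds named here, the single measured step, an at least 14-fold lower number from compound 1 to compound 2 (1.15 log units; beyond the scatter), is the only one recorded, and it shows that a change on this ring can move the read-out well beyond the scatter.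

Compound 3 `COc1ccc(-c2nnc(-c3c[nH]c4ccccc34)o2)cc1` is not yet measured. It differs from compound 1 by methoxy in place of hydrogen on an aromatic carbon. The measured step replaces the ring itself, whereas the change to compound 3 adds a group to the ring, so the step from compound 1 to compound 2 bears on it only as a sign that changes here register, not as a direct precedent for its size. The expected step is an at least 2.5-fold lower number from compound 1 to compound 3 (0.39 log units; beyond the scatter), a drop smaller than the measured one. Compound 3 is expected at 400000 nM, with a range from 80000 nM to 1000000 nM, and a fair chance that this assay again reports only a limit.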

Compound 3, half-maximal inhibitory concentration: > 1000000 nM
Compound 3 gave a limit, no number; the forecaster's own chance of this, stated with the estimate: 45%; middle value at least 2.5-fold (0.39 log units) away from the limit.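

Compound 1 and compound 3 both end at a limit in this assay and not at a number, so no step between them can be read: the limit of > 1000000 nM in this assay, at which 2 of the 3 values shown sit.

The compounds shown leave open whether methoxy in place of hydrogen on an aromatic carbon moves the read-out of this assay at all.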